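A few compounds are considered here, and "the series" means these few. Any claim that something is new, unique, unknown or untested is made for them only; others in the source may bear on it.

Of the compounds shown here, three have so far been measured in a functional assay on MGC-803 cells (Homo sapiens) for inhibition, read by MTT assay, with a stated time of 48 h; on this read-out higher numbers stand for weaker inhibition and lower numbers for stronger inhibition. Compound 1 `CCC(=O)N(Cc1ccc(OC)c(O)c1)c1cc(OC)c(OC)c(OC)c1` gives 50 nM, the lowest of the three numbers. Compound 2 `C/C=C/C(=O)N(Cc1cc(OC)c(OC)c(OC)c1)c1ccc(OC)c(O)c1` gives 6150 nM, and compound 3 `COc1ccc(CNc2cc(OC)c(OC)c(OC)c2)cc1C` gives 56800 nM; both numbers lie well beyond the scatter above that of compound 1, which is therefore the strongest inhibitor of the three. The next compound to be tested is compound 4 `C/C=C/C=C/C(=O)N(Cc1ccc(OC)c(O)c1)c1cc(OC)c(OC)c(OC)c1`, which differs from compound 1 in one place: penta-1,3-dien-1-yl in place of ethyl on a carbonyl carbon. For the measured compounds named here, no pair of measured compounds isolates a change of this kind, so the expectation rests on compound 1 alone. A modest weakening, somewhat beyond the scatter, is expected, amounting to a step of a 3.0-fold higher number from compound 1 to compound 4 (0.48 log units; beyond the scatter). Compound 4 is accordingly estimated at 150 nM, within a range from 30 nM to 1500 nM.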

Compound 4, half-maximal inhibitory concentration: 140 nM
Compound 4: the middle estimate sits 1.1-fold (0.03 log units) above what was measured, and the stated range covers the measured number.
By their numbers in this assay, from the lowest: compound 1; then compound 4; then compound 2; then compound 3.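

In this assay, for the compounds shown here, penta-1,3-dien-1-yl in place of ethyl on a carbonyl carbon gives a 2.8-fold higher number from compound 1 to compound 4 (0.45 log units; beyond the scatter), the first step to isolate a change at this place. The larger group, with its two double bonds, weakens inhibition only modestly, so this place accepts more than ethyl without a collapse in potency. Nothing at hand gives a reason for this step. Open, as far as these compounds go, is whether the step follows chain length or the double bonds, which a saturated pentyl chain would separate. Also open, from the compounds shown here alone, is how a chain ending in an amine or a carboxylic acid would fare here.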